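This account rests on a few compounds, and the source may have more. Where it says the series, first, only, none or still open, it means among the compounds named here.

Measured so far:
compound 1, `CC(C)Oc1ccc(NC(=O)CSc2nnc(Cc3nn(C)c(=O)c4ccccc34)n2C)cc1`: > 30000 nM
compound 2, `Cn1c(Cc2nn(C)c(=O)c3ccccc23)nnc1SCCCCCCCC(=O)Nc1ccc(I)cc1`: 1300 nM
compound 3, `Cn1c(Cc2nn(C)c(=O)c3ccccc23)nnc1SCC(=O)Nc1ccc(F)cc1F`: "not active" (no number reported)

Among the compounds with values here, in an assay on isolated protein (Mus musculus) for inhibition of IL15-IL15 receptor (Homo sapiens), read by resazurin assay, with stated times of 30 min and 2.5 days (a higher number here means a weaker inhibitor, a lower number a stronger inhibitor), compound 2 gives 1300 nM, the only plain number among the three. For compound 1 the read-out is a limit of the assay, > 30000 nM, not a number (the limit of > 30000 nM in this assay, at which 1 of the 3 values shown sits). Compound 3 is reported as "not active" (no number reported), with no number. Compound 4, `Cc1ccc(NC(=O)CCCCCCCSc2nnc(Cc3nn(C)c(=O)c4ccccc34)n2C)c(Cl)c1`, has not yet been measured. It differs from compound 2 in one place: 2-chloro-4-methylphenyl in place of 4-iodophenyl on an amide-type nitrogen. Within the data shown here, no pair of measured compounds differing in a single place is available to gauge a change of this kind, so the step in this assay is expected to be small, not clearly beyond the usual scatter. Compound 4 is therefore expected to give about 2500 nM, within 800 nM to 8000 nM. This expected step is a 1.9-fold higher number from compound 2 to compound 4 (0.28 log units; within the scatter).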

Compound 4, half-maximal inhibitory concentration: 2300 nM
The estimate for compound 4 lay 1.1-fold (0.04 log units) above the measured number, within the range that was stated.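

In this assay, putting 2-chloro-4-methylphenyl in place of 4-iodophenyl on the amide-type nitrogen gives a 1.8-fold higher number from compound 2 to compound 4 (0.25 log units; within the scatter). Within the data shown here, this is the first comparison here of compounds that differ in one place, and it shows that this position accepts either of these two rings with no difference beyond the usual scatter. Nothing measured here gives a reason for this result.

On these data alone, whether a ring carrying an amine or a carboxylic acid would read the same remains open. So does the reading for a plain phenyl ring.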